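A few compounds are considered here, and "the series" means these few. Any claim that something is new, unique, unknown or untested is made for them only; others in the source may bear on it.

Measured compounds:
Compound 1 `Cn1ccc2ccc(-c3cc(Nc4cnccc4C(=O)NCc4cncnc4)cc4nccnc34)cc21` gives 49500 nM in an assay on lysate for inhibition of 6-phosphofructo-2-kinase/fructose-2,6-bisphosphatase 3 (Homo sapiens), with stated times of 0.5 min and 45 min; on this read-out lower numbers stand for stronger inhibition and higher numbers for weaker inhibition.
Compound 2 `CC(=O)N1CCOC(CNC(=O)c2ccncc2Nc2cc(-c3ccc4ccn(C)c4c3)c3nccnc3c2)C1` gives > 100000 nM in this assay, which is a limit and not a number (the limit of > 100000 nM in this assay, at which 1 of the 2 values shown sits).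

Compound 2 thus stands only at a limit, with no number of its own. Compound 3 `CN1CCC(CNC(=O)c2ccncc2Nc2cc(-c3ccc4ccn(C)c4c3)c3nccnc3c2)C1` differs from compound 2 by 1-methylpyrrolidin-3-yl in place of 4-acetylmorpholin-2-yl on a saturated chain carbon bound to an amide-type nitrogen. Within the data shown here, the single measured step, an at least 2.0-fold higher number from compound 1 to compound 2 (0.30 log units; that floor lies within the scatter), concerns a different exchange and does not bear on this one, so no step beyond the scatter is expected in either direction. Compound 3 is expected to sit near the limit, an expected step of an at least 1.1-fold lower number from compound 2 to compound 3 (0.04 log units; that floor lies within the scatter). The estimate for compound 3 is 90000 nM, ranging from 25000 nM to 300000 nM.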

Compound 3, half-maximal inhibitory concentration: 24000 nM
For compound 3 the middle estimate is 3.8-fold (0.57 log units) above the measured one, and the stated range ends above it.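

This place, on a saturated chain carbon bound to an amide-type nitrogen, now shows a change beyond the scatter: 1-methylpyrrolidin-3-yl in place of 4-acetylmorpholin-2-yl gives an at least 4.1-fold lower number from compound 2 to compound 3 (0.61 log units; beyond the scatter). The same group in place of pyrimidin-5-yl gives a 2.1-fold lower number from compound 1 to compound 3 (0.31 log units; beyond the scatter), so in this assay an aromatic ring is not required here. Compound 2 stands at a limit and not a number, so the size of the first step stays a floor: the limit of > 100000 nM in this assay, at which 1 of the 3 values shown sits.

Open, on these data alone, is whether a primary amine, a carboxylic acid or a longer chain at this place would lower the number further.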